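A tert-butyl group on the benzoyl of compound 3

This account rests on a few compounds, and the source may have more. Where it says the series, first, only, none or still open, it means among the compounds named here.

Measured in a functional assay on PC-3 cells (Homo sapiens) for inhibition, read by MTT assay, with a stated time of 48 h; on this read-out higher numbers stand for weaker inhibition and lower numbers for stronger inhibition:
compound 1 `COc1cc(N(Cc2nc3ccccc3[nH]2)S(=O)(=O)c2ccc(Br)cc2)cc(OC)c1OC`: 6890 nM
compound 2 `Cc1ccc(N(Cc2nc3ccccc3[nH]2)S(=O)(=O)c2ccc(C)cc2)cc1`: 48900 nM
compound 3 `COc1cc(N(Cc2nc3ccccc3[nH]2)C(=O)c2ccccc2)cc(OC)c1OC`: > 50000 nM

Compound 3 stands at the bottom of these three: in this assay compound 3 gives > 50000 nM, which is a limit of the assay and not a number (the limit of > 50000 nM in this assay, at which 1 of the 3 values shown sits). Compound 1 gives 6890 nM and compound 2 gives 48900 nM. For the measured compounds named here, the one step that touches compound 3 is an at least 7.2-fold higher number from compound 1 to compound 3 (0.86 log units; beyond the scatter), a change of the group on the nitrogen. Compound 4 `COc1cc(N(Cc2nc3ccccc3[nH]2)C(=O)c2ccc(C(C)(C)C)cc2)cc(OC)c1OC` differs from compound 3 by tert-butyl in place of hydrogen on an aromatic carbon. Going by the values given here, no measured step concerns a substituent on the benzoyl ring; the step of an at least 7.2-fold higher number from compound 1 to compound 3 (0.86 log units; beyond the scatter) swaps the whole group and says nothing about adding a tert-butyl to it. In this assay compound 4 is therefore expected to show no step beyond the scatter, a number no higher from compound 3 to compound 4 (the limit leaves the size open), and since compound 3 gives only a limit, compound 4 is expected to give 50000 nM (range 15000 nM to 150000 nM), quite possibly again only as a limit.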

Compound 4, half-maximal inhibitory concentration: 46000 nM
Compound 4: the middle estimate sits 1.1-fold (0.04 log units) above what was measured; low and high end bracket the measured number.
By their numbers in this assay, from the lowest: compound 1; then compounds 4 and 2 (each within the scatter of the next). At a limit, above all of these: compound 3.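

In this assay, compound 4 is the only compound shown with a substituent on the benzoyl ring, and with tert-butyl para to a large group it gives a measured number (46000 nM). Compound 3 stays at a limit of the assay, which is not a number (> 50000 nM). Adding the tert-butyl gives a step (an at least 1.0-fold lower number from compound 3 to compound 4 (0.03 log units; that floor lies within the scatter)) that is not shown to exceed the scatter, and the true size of that step stays unreadable: the limit of > 50000 nM in this assay, at which 1 of the 4 values shown sits.

From the compounds shown here alone, whether a smaller group at this place, such as a bromine or a methyl, would give a readable number remains open. So does the effect of an amine or a carboxylic acid on the same benzoyl ring, and the compounds shown say nothing about either.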